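The compounds below may be only part of what the source reports. "The series", "measured", "known", "first", "only" and "open" are said of these compounds alone.

Measured so far in a functional assay on A549 cells (Homo sapiens) for antiproliferative activity, read by MTT assay, with a stated time of 72 h; on this read-out higher numbers stand for weaker inhibition and lower numbers for stronger inhibition:
Compound 1 `COc1cc2ncnc(Nc3ccc(F)c(Cl)c3)c2cc1OCCCCC(=O)Nc1ccc(S(N)(=O)=O)cc1` gives 15500 nM.
Compound 2 `COc1cc2ncnc(Nc3ccc(F)cc3)c2cc1OCCCCC(=O)Nc1ccc(S(N)(=O)=O)cc1` gives only an assay limit, > 40000 nM.

Compound 2 thus sits at the limit of > 40000 nM in this assay, at which 1 of the 2 values shown sits, so its true number is not fixed. Compound 3 `COc1cc2ncnc(Nc3ccc(Cl)cc3)c2cc1OCCCCC(=O)Nc1ccc(S(N)(=O)=O)cc1` differs from it by chloro in place of fluoro on an aromatic carbon. For the measured compounds named here, the single measured step bearing on this, an at least 2.5-fold higher number from compound 1 to compound 2 (0.41 log units; beyond the scatter), removed a chloro and gave a higher number; putting a chloro back in compound 3 is therefore expected to lower the number in this assay, the size uncertain given the limit for compound 2. Compound 3 is expected near 20000 nM, from 8000 nM to 60000 nM. The expected step is an at least 2.0-fold lower number from compound 2 to compound 3 (0.30 log units; that floor lies within the scatter).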

Compound 3, half-maximal inhibitory concentration: > 40000 nM
Compound 3: a limit, no number; the forecaster's own chance of this, stated with the estimate: 35%; middle value at least 2.0-fold (0.30 log units) from the limit.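

In this assay compound 3 also gives only a limit, > 40000 nM, so the step from compound 2 cannot be read: the limit of > 40000 nM in this assay, at which 2 of the 3 values shown sit. Going from 3-chloro-4-fluorophenyl to 4-chlorophenyl on the nitrogen gives an at least 2.5-fold higher number from compound 1 to compound 3 (0.41 log units; beyond the scatter). For the compounds shown here, a single chloro on this carbon, para to a large group, therefore does not match compound 1, the only compound of the three with a number.

As far as these compounds go, how far compound 2 and compound 3 lie past the limit stays open. Also open, from the compounds shown here alone, is whether bromo, methyl or methoxy on this carbon would return a number.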